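Vinyl in Place of Phenyl on a Shared Core

The compounds below may be only part of what the source reports. "The series", "measured", "known", "first", "only" and "open" are said of these compounds alone.

Of the compounds shown here, two have been tested in a functional assay on KYSE-70 cells for antiproliferative activity against KYSE-70 cell line (Homo sapiens), read by MTT assay, with a stated time of 72 h; a lower number here means a stronger inhibitor, a higher number a weaker inhibitor. For compound 1 `O=C(Nc1ccc(F)cc1F)c1cc(=O)[nH]c2cc(Br)ccc12` the result is a limit of the assay, > 20000 nM. For compound 2 `O=C(Nc1cccc(F)c1)c1cc(=O)[nH]c2cc(-c3ccccc3)ccc12` the result is likewise a limit, > 20000 nM. Compound 2 thus stands where both measured values sit, at the limit of > 20000 nM in this assay, at which 2 of the 2 values shown sit, so no number is known for either compound. Compound 3 `C=Cc1ccc2c(C(=O)Nc3cccc(F)c3)cc(=O)[nH]c2c1` differs from compound 2 by vinyl in place of phenyl on an aromatic carbon. Going by the values given here, no measured step frames this change, and no shift beyond the scatter is expected in this assay. The step that the limit leaves unreadable from compound 2 to compound 3 is expected to be flat. Compound 3 is expected near 25000 nM, within 5000 nM to 100000 nM.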

Compound 3, half-maximal inhibitory concentration: 9700 nM
Compound 3: the middle estimate sits 2.6-fold (0.41 log units) above what was measured, within the range that was stated.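

Replacing phenyl with vinyl at this position in this assay gives an at least 2.0-fold lower number from compound 2 to compound 3 (0.31 log units; beyond the scatter). Compound 3 therefore yields a real number on the shared core, showing that this aromatic carbon can change the read-out. How large the step truly is cannot be said, because compound 2 stands at a limit of the assay: the limit of > 20000 nM in this assay, at which 2 of the 3 values shown sit.

Going by these compounds, what an ethyl group, a methyl group or an amine would give at this position stays open. The compounds shown cannot separate the double bond of vinyl from the loss of the ring.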